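Furan for Thiophene on Two Nucleoside Cores

A few compounds are considered here, and "the series" means these few. Any claim that something is new, unique, unknown or untested is made for them only; others in the source may bear on it.

Compound 1 `COc1ncnc2c1c(-c1ccoc1)cn2[C@@H]1O[C@H](CO)[C@@H](O)[C@H]1O`: 110 nM; compound 2 `COc1ncnc2c1c(-c1cccs1)cn2[C@@H]1O[C@H](CO)[C@@H](O)[C@H]1O`: 80 nM; compound 3 `Nc1nc2c(c(-c3cccs3)cn2[C@@H]2O[C@H](CO)[C@@H](O)[C@H]2O)c(=O)[nH]1`: > 20000 nM.

In a functional assay on HCT-116 cells (Homo sapiens), read by MTT assay, with a stated time of 72 h (on this read-out higher numbers stand for weaker inhibition and lower numbers for stronger inhibition), compound 2 gives 80 nM and compound 1 gives 110 nM. The change between them is furan-3-yl in place of thiophen-2-yl on an aromatic carbon; the step it made is a 1.4-fold higher number from compound 2 to compound 1 (0.14 log units; within the scatter).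

Compound 3 is reported only as a limit of this assay, > 20000 nM, and not as a number. The difference between the core of compound 3 and the core of compound 2 is not broken down here.

Compound 4 `Nc1nc2c(c(-c3ccoc3)cn2[C@@H]2O[C@H](CO)[C@@H](O)[C@H]2O)c(=O)[nH]1` has not been measured in this assay. It differs from compound 3 by furan-3-yl in place of thiophen-2-yl on an aromatic carbon, the same change as from compound 2 to compound 1, at the same place. Because compound 3 sits at the limit (the limit of > 20000 nM in this assay, at which 1 of the 3 values shown sits), and the measured step of a 1.4-fold higher number from compound 2 to compound 1 (0.14 log units; within the scatter) lay within the scatter, compound 4 is expected to stay at the limit as well, with an estimated step that the limit leaves unreadable from compound 3 to compound 4. The estimated value for compound 4 is 30000 nM, between 12000 nM and 80000 nM.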

Compound 4, half-maximal inhibitory concentration: 14200 nM
Compound 4: middle estimate off by 2.1-fold (0.32 log units), on the high side, and the stated range covers the measured number.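

In this assay, furan-3-yl in place of thiophen-2-yl on the second core gives an at least 1.4-fold lower number from compound 3 to compound 4 (0.14 log units; that floor lies within the scatter), and that floor is all that can be read of the step on this core. Set beside the step on the core of compound 1, this allows only a loose comparison: the same change on two cores in this assay, a 1.4-fold higher number (0.14 log units; within the scatter) from compound 2 to compound 1 and an at least 1.4-fold lower number (0.14 log units; that floor lies within the scatter) from compound 3 to compound 4; the limit leaves it open whether they differ. From the compounds shown here alone, the change therefore turns a limit for compound 3 into a measured number for compound 4, but the series does not show whether it carries over with the same size, and its true size on this core stays unknown: the limit of > 20000 nM in this assay, at which 1 of the 4 values shown sits.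

The compounds shown leave open how other rings on this aromatic carbon, such as furan-2-yl, thiophen-3-yl or phenyl, would fare on either core. They also leave open what an amine or a longer alkoxy chain in place of the methoxy group on the core of compound 1 would do to the number in this assay.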